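The source may hold more compounds than are shown below. What is called first, only, known or untested is meant among the compounds shown, and "the series" means these compounds.

Compound 1 `CN1CCN(C(=O)c2cc3c(Nc4ccc(OC(F)(F)F)cc4)ncnc3s2)CC1`: 2690 nM
Compound 2 `O=C(O)c1cc2c(Nc3ccc(OC(F)(F)F)cc3)ncnc2s1`: > 10000 nM

Both compounds were tested in an ADME assay on BaF3 cells (Mus musculus) for cytotoxicity; on this read-out lower numbers stand for an effect already at smaller amounts and higher numbers for an effect only at larger amounts of compound. Compound 2 stands at > 10000 nM, which is a limit of the assay and not a number.

Compound 3 `O=C(NCCO)c1cc2c(Nc3ccc(OC(F)(F)F)cc3)ncnc2s1` differs from compound 2 in one place: (2-hydroxyethyl)amino in place of hydroxy on a carbonyl carbon. Put simply, (2-hydroxyethyl)amino takes the place of hydroxy on a carbonyl carbon, turning carboxy into (2-hydroxyethyl)carbamoyl.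

Among the measured compounds shown here, one measured step bears on this change: an at least 3.7-fold higher number from compound 1 to compound 2 (0.57 log units; beyond the scatter). That step, which lies beyond the scatter, also exchanges the group on the carbonyl carbon, with hydroxy replacing 4-methylpiperazin-1-yl. Compound 3 moves the opposite way, from hydroxy to an amino group, although not to the same one. For the measured compounds named here, with compound 1 at 2690 nM as the only guide, compound 3 is expected to give a lower number than compound 2, probably not as low as compound 1. The assay may still report only a limit. The expected change is an at least 2.0-fold lower number from compound 2 to compound 3 (0.30 log units; that floor lies within the scatter). Compound 3 is estimated at 5000 nM, with an expected range from 1800 nM to 12000 nM.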

Compound 3, half-maximal effective concentration: > 10000 nM
Compound 3 gave a limit, no number; the forecaster's own chance of this, stated with the estimate: 35%; at least 2.0-fold (0.30 log units) between middle value and limit.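

In this assay compound 3 gives > 10000 nM, which is a limit of the assay and not a number. Putting (2-hydroxyethyl)amino in place of 4-methylpiperazin-1-yl on the carbonyl carbon gives an at least 3.7-fold higher number from compound 1 to compound 3 (0.57 log units; beyond the scatter), so among these compounds an amino group on the carbonyl carbon does not by itself go with a lower number: the identity of that group matters, and only the 4-methylpiperazin-1-yl group of compound 1 gives a measurable value. The step from compound 2 to compound 3 cannot be read, because both compounds end at the same edge of the measurable range: the limit of > 10000 nM in this assay, at which 2 of the 3 values shown sit.

As far as these compounds go, how far compound 2 and compound 3 lie beyond that limit remains unknown, so hydroxy and (2-hydroxyethyl)amino cannot be ranked against each other. From the compounds shown here alone, it also remains open which part of 4-methylpiperazin-1-yl goes with the lower number, a question that a piperazin-1-yl group without the methyl, a morpholin-4-yl group or a longer chain ending in a dimethylamino group could help to answer.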